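Carbonyl-side replacements in a series without a clear trend

The source may hold more compounds than are shown below. What is called first, only, known or untested is meant among the compounds shown, and "the series" means these compounds.

In a functional assay on A549 cells (Homo sapiens) for antiproliferative activity, read by XTT assay, with a stated time of 72 h (a higher number here means a weaker inhibitor, a lower number a stronger inhibitor), compound 1 `COc1ccc(-c2cc3ccccc3nc2/C=C/C(=O)c2ccc(OC)cc2OC)cc1` gives 7990 nM, compound 2 `COc1ccc(-c2cc3ccccc3nc2/C=C/C(=O)c2c(OC)cccc2OC)cc1` gives 7410 nM and compound 3 `COc1ccc(-c2cc3ccccc3nc2/C=C/C(=O)c2ccccn2)cc1` gives 6140 nM. Compound 2 therefore lies within the scatter of both other compounds. Compound 4 `COc1ccc(-c2cc3ccccc3nc2/C=C/C(=O)c2ccc(Br)s2)cc1` carries 5-bromothiophen-2-yl in place of 2,6-dimethoxyphenyl on a carbonyl carbon. Three measured replacements at this place bear on the change: a 1.1-fold lower number from compound 1 to compound 2 (0.03 log units; within the scatter), a 1.3-fold lower number from compound 1 to compound 3 (0.11 log units; within the scatter) and a 1.2-fold lower number from compound 2 to compound 3 (0.08 log units; within the scatter). Among the measured compounds shown here, all three stay within the scatter, although no measured compound contains sulfur or bromine. No shift beyond the scatter is therefore expected. The expected change is a 1.3-fold lower number from compound 2 to compound 4 (0.11 log units; within the scatter). Compound 4 is estimated at 5800 nM, with an expected range of 2500 nM to 12000 nM.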

Compound 4, half-maximal inhibitory concentration: 6250 nM
Beside the measured number, compound 4's estimate is 1.1-fold (0.03 log units) below it; the range from low to high includes it.
By their numbers in this assay, from the lowest: compounds 3, 4, 2 and 1 (each within the scatter of the next).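

Sulfur and bromine now appear on the carbonyl carbon side, carried on a five-membered aromatic ring, yet all three new steps stay within the scatter (a 1.2-fold lower number from compound 2 to compound 4 (0.07 log units; within the scatter); a 1.0-fold higher number from compound 3 to compound 4 (0.01 log units; within the scatter); a 1.3-fold lower number from compound 1 to compound 4 (0.11 log units; within the scatter)). The flat picture from the two dimethoxyphenyl groups and pyridin-2-yl therefore extends to 5-bromothiophen-2-yl, a group with fewer heavy atoms and a different ring size. Nothing available explains this flatness.

Going by these compounds, it remains open whether any group at this place moves the number beyond the scatter. A carboxylic acid, an amine or a longer chain there would test this.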